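From piperidinylcarbonyl to dimethylaminomethyl on the urea chain

The source may report more compounds than this note shows. Statements on the series, on what has been measured and on what is new or still open speak of the compounds shown alone.

Measured so far in a functional assay on A549 cells (Homo sapiens) for cytotoxicity, read by MTT assay, with a stated time of 72 h; on this read-out lower numbers stand for stronger inhibition and higher numbers for weaker inhibition:
- compound 1 `COc1ncc(-c2ccc3nc(NC(=O)NCC(=O)N4CCCCC4)nn3c2)cc1NS(=O)(=O)c1ccc(F)cc1`: 2060 nM
- compound 2 `COc1ncc(-c2ccc3nc(NC(=O)NCCN4CCCC4)nn3c2)cc1NS(=O)(=O)c1ccc(F)cc1`: 960 nM
- compound 3 `COc1ncc(-c2ccc3nc(NC(=O)NCC(=O)N4CCCC4)nn3c2)cc1NS(=O)(=O)c1ccc(F)cc1`: 2190 nM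

Compound 1 gives the second highest of the three numbers. Its nearest neighbour is compound 3, with a 1.1-fold higher number from compound 1 to compound 3 (0.03 log units; within the scatter), a gap that stays within the scatter. The furthest is compound 2, with a 2.1-fold lower number from compound 1 to compound 2 (0.33 log units; beyond the scatter).

Compound 4 `COc1ncc(-c2ccc3nc(NC(=O)NCCN(C)C)nn3c2)cc1NS(=O)(=O)c1ccc(F)cc1` is not yet measured. It differs from compound 1 in one place: (dimethylamino)methyl in place of (piperidin-1-yl)carbonyl on a saturated chain carbon bound to an amide-type nitrogen.

Among the measured compounds shown here, two measured steps bear on this change, since both exchange a carbonyl-linked ring for a methylene-linked amine on the same chain carbon. The first is a 2.1-fold lower number from compound 1 to compound 2 (0.33 log units; beyond the scatter); the second, in the opposite direction, is a 2.3-fold higher number from compound 2 to compound 3 (0.36 log units; beyond the scatter). Both are modest and beyond the scatter, and they point the same way. A similar step is therefore expected for compound 4, namely a 1.9-fold lower number from compound 1 to compound 4 (0.27 log units; within the scatter), with the number landing near that of compound 2.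

Compound 4 is thus estimated at 1100 nM, in a range from 500 nM to 2500 nM.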

Compound 4, half-maximal inhibitory concentration: 800 nM
Estimate against measurement, compound 4: 1.4-fold (0.14 log units) above; the range from low to high includes it.
By their numbers in this assay, from the lowest: compounds 4 and 2 (each within the scatter of the next); then compounds 1 and 3 (each within the scatter of the next).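

In this assay, the lower number does not depend on the (pyrrolidin-1-yl)methyl group alone: (dimethylamino)methyl in place of (piperidin-1-yl)carbonyl gives a 2.6-fold lower number from compound 1 to compound 4 (0.41 log units; beyond the scatter), and in place of (pyrrolidin-1-yl)carbonyl it gives a 2.7-fold lower number from compound 3 to compound 4 (0.44 log units; beyond the scatter), both modest steps beyond the scatter. The ring on the amine is not required, since dimethylamino in place of pyrrolidin-1-yl gives a 1.2-fold lower number from compound 2 to compound 4 (0.08 log units; within the scatter), which stays within the scatter. Among these four compounds, both chains ending in an amine give lower numbers than both carbonyl-linked rings, with no compound going against this, but no measurement shown here explains the difference.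

The compounds shown leave open how a morpholin-4-yl or 4-methylpiperazin-1-yl group would read on this chain. They also leave open whether a longer chain ending in dimethylamino would keep the lower numbers.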